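Working notes: from compound 3 to compound 4

The source may hold more compounds than are shown below. What is called first, only, known or untested is meant among the compounds shown, and "the series" means these compounds.

Measured in a functional assay on U-937 cells (Homo sapiens), read by cAMP accumulation; a higher number here means that more compound is needed for the effect, a lower number that less compound is needed:
compound 1 `CCc1nn(-c2ccc(F)cc2)c2c1CCN(c1ccccc1)C2=O`: 880 nM
compound 2 `CCc1nn(C2CCCC2)c2c1CCN(c1ccccc1)C2=O`: 70 nM
compound 3 `CCc1nn(-c2ccc(F)cc2)c2c1CCN(c1ccccc1OC)C2=O`: 3210 nM

Compound 3 has the highest number of the three, at 3210 nM. Compound 4 `CCc1nn(-c2ccc(F)cc2)c2c1CCN(c1ccc(C)cc1)C2=O` carries 4-methylphenyl in place of 2-methoxyphenyl on an amide-type nitrogen in a ring. The most relevant measured step is a 3.6-fold higher number from compound 1 to compound 3 (0.56 log units; beyond the scatter), which is modest. Losing the methoxy may reverse about that much, towards compound 1 at 880 nM. The large 13-fold lower number from compound 1 to compound 2 (1.10 log units; beyond the scatter) concerns an aromatic nitrogen, which is unchanged here. Within the data shown here, no measured compound carries 4-methylphenyl, so its contribution is unknown. A modest step to a lower number is therefore expected in this assay. The estimated change is a 3.6-fold lower number from compound 3 to compound 4 (0.55 log units; beyond the scatter). The estimated value for compound 4 is 900 nM, with an expected range of 300 nM to 2800 nM.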

Compound 4, half-maximal effective concentration: 500 nM
For compound 4 the middle estimate is 1.8-fold (0.26 log units) above the measured one; low and high end bracket the measured number.
By their numbers in this assay, from the lowest: compound 2; then compounds 4 and 1 (each within the scatter of the next); then compound 3.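

In this assay, the step of a 1.8-fold lower number from compound 1 to compound 4 (0.25 log units; within the scatter) shows that a methyl on the phenyl at the amide-type nitrogen leaves the number within the scatter, so not every substituent there raises it. The change from 2-methoxyphenyl to 4-methylphenyl gives a 6.4-fold lower number from compound 3 to compound 4 (0.81 log units; beyond the scatter), which ties the high number of compound 3 to 2-methoxyphenyl among the groups shown. Nothing available explains this difference. Going by these compounds, whether it follows the methoxy itself or its place on the phenyl stays open, as does how an amine or a carboxylic acid on that phenyl would read in this assay.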